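Compound 3: loss of the 4-methoxybenzyl group

The source may hold more compounds than are shown below. What is called first, only, known or untested is meant among the compounds shown, and "the series" means these compounds.

In an ADME assay on Vero cells (Chlorocebus sabaeus) for cytotoxicity, read by MTT assay, with a stated time of 24 h (on this read-out higher numbers stand for lower toxicity in this test and lower numbers for higher toxicity in this test), compound 1 (`Nc1nc(N)c2cc(N(Cc3ccc(OC(F)(F)F)cc3)Cc3ccc(OC(F)(F)F)cc3)ccc2n1`) gives > 200000 nM as a limit of the assay. Compound 2 (`COc1ccc(CN(Cc2ccc(OC(F)(F)F)cc2)c2ccc3nc(N)nc(N)c3c2)cc1`) gives > 200000 nM as a limit too, so it stands without a number. Compound 3 (`Nc1nc(N)c2cc(NCc3ccc(OC(F)(F)F)cc3)ccc2n1`) differs from compound 2 by hydrogen in place of 4-methoxybenzyl on a nitrogen on an aromatic ring and carries hydrogen in place of 4-methoxybenzyl on a nitrogen on an aromatic ring. Among the compounds with values here, the one measured step that the two limits leave unreadable from compound 1 to compound 2 lies at another place and hands on no size. No change beyond the scatter is therefore expected, and the estimated step is an at least 1.3-fold lower number from compound 2 to compound 3 (0.12 log units; that floor lies within the scatter) for now. Compound 3 is expected at 150000 nM within the estimated range 40000 nM to 400000 nM in this assay when measured.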

Compound 3, half-maximal cytotoxic concentration: 182000 nM
Compound 3: middle estimate off by 1.2-fold (0.08 log units), on the low side; the range from low to high includes it.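

Within the data shown here, removing one benzyl group from this nitrogen leaves a secondary aromatic amine and gives the first real number in this assay. The steps are an at least 1.0-fold lower number from compound 2 to compound 3 (0.04 log units; that floor lies within the scatter) for loss of 4-methoxybenzyl and an at least 1.0-fold lower number from compound 1 to compound 3 (0.04 log units; that floor lies within the scatter) for loss of 4-(trifluoromethoxy)benzyl, so a second benzyl group on this nitrogen is not needed for the read-out to stay in this high range. Both sizes are only floors, as the two starting compounds are limits and not numbers: the limit of > 200000 nM in this assay, at which 2 of the 3 values shown sit.

Still open, going by these compounds, is how a longer chain on this nitrogen would read. The same holds for a carboxylic acid or an amine on the remaining benzyl ring in place of trifluoromethoxy.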